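Carboxy in Place of Methyl: An Expected Step

A few compounds are considered here, and "the series" means these few. Any claim that something is new, unique, unknown or untested is made for them only; others in the source may bear on it.

Three measured compounds share one core and were tested in a functional assay on HEK293 cells for antagonist activity at transient receptor potential cation channel subfamily V member 1 (Rattus norvegicus), read by calcium flux; a higher number here means a weaker inhibitor, a lower number a stronger inhibitor. Compound 1 `FC(F)(F)c1ccc(Nc2ncnc3sc(Nc4c(Cl)cccc4Cl)nc23)cc1` gives 3 nM. Compound 2 `FC(F)(F)c1ccc(Nc2ncnc3sc(Nc4ccccc4C(F)(F)F)nc23)cc1` gives 37 nM in this assay, and compound 3 `Cc1ccc(Nc2ncnc3sc(Nc4c(Cl)cccc4Cl)nc23)cc1` gives 32 nM. Compound 3 therefore stands second highest of the three numbers, close to compound 2 and far from compound 1, as the step of an 11-fold higher number from compound 1 to compound 3 (1.03 log units; beyond the scatter) shows. Compound 4 `O=C(O)c1ccc(Nc2ncnc3sc(Nc4c(Cl)cccc4Cl)nc23)cc1` differs from compound 3 in one place: carboxy in place of methyl on an aromatic carbon. Going by the values given here, no measured step exchanges methyl for carboxy, so there is no direct precedent. The two measured steps, an 11-fold higher number from compound 1 to compound 3 (1.03 log units; beyond the scatter) and a 12-fold higher number from compound 1 to compound 2 (1.09 log units; beyond the scatter), both show that changing a single group on either outer ring moves the number by a large amount. A large step is therefore expected here too, most likely toward a higher number, estimated as a 31-fold higher number from compound 3 to compound 4 (1.49 log units; beyond the scatter). Compound 4 is expected to give about 1000 nM in this assay, within a range from 150 nM to 8000 nM.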

Compound 4, half-maximal inhibitory concentration: > 5000 nM
Compound 4: a limit, no number; the forecaster's own chance of this, stated with the estimate: 25%; middle value at least 5.0-fold (0.69 log units) away from the limit.
By their numbers in this assay, from the lowest: compound 1; then compounds 3 and 2 (each within the scatter of the next). At a limit, above all of these: compound 4.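

In this assay compound 4 has no number, only a limit: the limit of > 5000 nM in this assay, at which 1 of the 4 values shown sits.

Carboxy at this place on the ring gives an at least 150-fold higher number from compound 3 to compound 4 (2.19 log units; beyond the scatter), and measured against trifluoromethyl it gives an at least 1600-fold higher number from compound 1 to compound 4 (3.22 log units; beyond the scatter). The earlier compounds shown here showed that this position responds to a change of group, and these steps show that the response can be far larger than the one seen between trifluoromethyl and methyl; the entering carboxy adds a hydrogen-bond donor and a hydrogen-bond acceptor where methyl has neither, but these compounds cannot tell which feature of carboxy matters.

From the compounds shown here alone, how a methyl ester, a primary amide or a nitrile would read at this same place remains open. Also open, going by these compounds, is whether carboxy would cost as much with 2-(trifluoromethyl)phenyl in place of 2,6-dichlorophenyl on the other side of the shared core.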